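The source may hold more compounds than are shown below. What is called first, only, known or untested is meant among the compounds shown, and "the series" means these compounds.

Compound 1 `O=C(O)c1c(O)cccc1CCc1ccc2ccccc2c1` gives in an ADME assay on HEK293 cells (Homo sapiens) for cytotoxicity, read by resazurin assay, with a stated time of 24 h (a lower number here means that less compound is tolerated, a higher number that more compound is tolerated), a limit of the assay, > 100000 nM.
Compound 2 `Cc1cc(O)c(C(=O)O)c(CCc2ccc3ccccc3c2)c1` gives in this assay 40000 nM.
Compound 3 `COc1cccc(C=Cc2ccc3ccccc3c2)c1C(=O)O` gives in this assay a limit of the assay, > 100000 nM.

The measured step is an at least 2.5-fold lower number from compound 1 to compound 2 (0.39 log units; beyond the scatter), made by methyl in place of hydrogen on an aromatic carbon. Compound 4 `COc1cc(C)cc(C=Cc2ccc3ccccc3c2)c1C(=O)O` is not yet measured; it differs from compound 3 by methyl in place of hydrogen on an aromatic carbon. This is the same kind of change as that from compound 1 to compound 2, though the surroundings differ: in compound 2 the methyl sits meta to a hydroxy group, in compound 4 meta to a methoxy group. How the cores of compound 1 and compound 3 differ is not broken down here. Since compound 3 sits at the limit of > 100000 nM in this assay, at which 2 of the 3 values shown sit, the step from compound 3 to compound 4 is expected to be an at least 1.4-fold lower number from compound 3 to compound 4 (0.15 log units; that floor lies within the scatter), resting on the step from compound 1 to compound 2. Compound 4 is therefore estimated at 70000 nM.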

Compound 4, half-maximal cytotoxic concentration: 119000 nM
Beside the measured number, compound 4's estimate is 1.7-fold (0.23 log units) below it; the range from low to high includes it.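

In this assay compound 3 gives > 100000 nM, which is a limit of the assay, and because of that limit no step to compound 4 can be read: the limit of > 100000 nM in this assay, at which 2 of the 4 values shown sit.

As far as these compounds go, whether methyl in place of hydrogen on an aromatic carbon changes the number on the core of compound 3 stays open.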